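The source may report more compounds than this note shows. Statements on the series, on what has been measured and on what is new or still open speak of the compounds shown alone.

Measured so far:
compound 1 `N=C(N)c1ccc(-c2ccc(-c3cc(Cl)cc(Cl)c3)s2)s1` — 2390 nM
compound 2 `COc1ccc(-c2ccc(-c3ccc(C(=N)N)o3)o2)cc1` — 3190 nM

In a functional assay on OVCAR-8 cells (Homo sapiens) for inhibition, read by sulforhodamine B assay, with a stated time of 48 h (a higher number here means a weaker inhibitor of growth, a lower number a stronger inhibitor of growth), compound 2 gives the higher of the two numbers, but its gap to compound 1 is within the scatter, so no order between them is read. Compound 3 `N=C(N)c1ccc(-c2ccc(-c3ccccc3)o2)o1` differs from compound 2 in one place: hydrogen in place of methoxy on an aromatic carbon. Going by the values given here, no measured pair shows this change, so there is nothing to size the step from; the expectation is a step no larger than the scatter, in either direction. Compound 3 is therefore expected at 3500 nM, range 1500 nM to 8000 nM, a step of a 1.1-fold higher number from compound 2 to compound 3 (0.04 log units; within the scatter).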

Compound 3, concentration for 50% growth inhibition: 4000 nM
Compound 3: the middle estimate sits 1.1-fold (0.06 log units) below what was measured, within the range that was stated.
By their numbers in this assay, from the lowest: compounds 1, 2 and 3 (each within the scatter of the next).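

Hydrogen in place of methoxy on this aromatic carbon, para to a large group, gives a 1.3-fold higher number from compound 2 to compound 3 (0.10 log units; within the scatter) in this assay. Going by these compounds alone, this pair is the first size for the change, and it shows that the methoxy can go without a step beyond the scatter. No measurement on hand bears on the reason for this result.

One pair leaves open whether an amine, a carboxylic acid or a longer chain at this position would give a step beyond the scatter. Also open, on these data alone, is whether the same change reads alike on the core of compound 1.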